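A Smaller Ring on the Ether Arm: Compound 3 to 4

A few compounds are considered here, and "the series" means these few. Any claim that something is new, unique, unknown or untested is made for them only; others in the source may bear on it.

Of the compounds shown here, three sharing one core have been tested in a functional assay (blood) for inhibition, with Homo sapiens as the target; on this read-out higher numbers stand for weaker inhibition and lower numbers for stronger inhibition. Compound 1 `CCCC(Oc1ccc2c(c1)c(SC(C)(C)C)c(CC(C)(C)C(=O)O)n2Cc1ccc(Cl)cc1)c1ccc2ccccc2n1` gives > 3000 nM in this assay, which is a limit of the measurement and not a number. Compound 2 `CC(C)(C)Sc1c(CC(C)(C)C(=O)O)n(Cc2ccc(Cl)cc2)c2ccc(OCc3cc4ccccc4cn3)cc12` gives > 3000 nM in this assay, again a limit rather than a number. Among the compounds with values here, compound 3 `CC(C)(C)Sc1c(CC(C)(C)C(=O)O)n(Cc2ccc(Cl)cc2)c2ccc(OCc3nc4ccccc4o3)cc12` is the one compound with a true number, giving 2500 nM in this assay. Compound 1 and compound 2 instead sit at the limit of > 3000 nM in this assay, at which 2 of the 3 values shown sit. Within the data shown here, the only measured step is an at least 1.2-fold lower number from compound 2 to compound 3 (0.07 log units; that floor lies within the scatter), and it stays within the scatter.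

Compound 4 `CC(C)(C)Sc1c(CC(C)(C)C(=O)O)n(Cc2ccc(Cl)cc2)c2ccc(OCc3cccs3)cc12` has not yet been measured. The change from compound 3 is thiophen-2-yl in place of 1,3-benzoxazol-2-yl on a saturated chain carbon bound to an oxygen on an aromatic ring. Among the measured compounds shown here, no measured step covers this exchange; the one step available swapped one ring for another on the saturated chain carbon bound to an oxygen on an aromatic ring without moving beyond the scatter. On that footing compound 4 is expected to show a 1.2-fold higher number from compound 3 to compound 4 (0.08 log units; within the scatter), with a real chance that the measurement again returns only a limit. Compound 4 is therefore estimated at 3000 nM, in a range from 1500 nM to 6000 nM.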

Compound 4, half-maximal inhibitory concentration: > 3000 nM
Compound 4 ended at the assay's limit (the forecaster's own chance of this, stated with the estimate: 50%); the middle value lies on the limit itself.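

In this assay, replacing 1,3-benzoxazol-2-yl with thiophen-2-yl removes the six-membered aromatic ring of carbon only and gives an at least 1.2-fold higher number from compound 3 to compound 4 (0.07 log units; that floor lies within the scatter). The step from compound 2 to compound 4 cannot be read, as both of its ends are limits. Compound 4 adds a single five-membered ring to the groups tried at this place, and this smaller group also fails to give a true number, leaving compound 3 as the only exception to the following: the limit of > 3000 nM in this assay, at which 3 of the 4 values shown sit.

On these data alone, it remains open whether any group at this place can move the number beyond the scatter. A plain phenyl ring, a pyridine ring or an amine on the saturated chain carbon could help to answer this, as each would test a different kind of group on the same shared core.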